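Pyrazolo-fused enone series: reversed enone, phenyl in place of anisyl

A few compounds are considered here, and "the series" means these few. Any claim that something is new, unique, unknown or untested is made for them only; others in the source may bear on it.

Measured so far in a functional assay on DU-145 cells (Homo sapiens) for antiproliferative activity, read by MTT assay, with a stated time of 24 h; on this read-out higher numbers stand for weaker inhibition and lower numbers for stronger inhibition:
compound 1 `COc1ccc(C(=O)/C=C/c2cc(-c3cc(OC)c(OC)c(OC)c3)n3nc(-c4ccccc4)cc3n2)cc1` gives 25200 nM
compound 2 `COc1cc(C(=O)/C=C/c2cc(-c3cc(OC)c(OC)c(OC)c3)n3nc(-c4ccccc4)cc3n2)cc(OC)c1OC` gives 34900 nM
compound 3 `COc1ccc(-c2cc(/C=C/C(=O)c3cc(OC)c(OC)c(OC)c3)nc3cc(-c4ccccc4)nn23)cc1OC` gives 8300 nM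

On these numbers compound 1 sits second highest of the three; compound 2 is close to it, while compound 3 lies further off. The new member, compound 4 `COc1cc(-c2cc(C(=O)/C=C/c3ccccc3)nc3cc(-c4ccccc4)nn23)cc(OC)c1OC`, differs from compound 1 by (2-phenylethenyl)carbonyl in place of 2-((4-methoxyphenyl)carbonyl)ethenyl on an aromatic carbon. The measured steps do not cover this change directly. The step of a 1.4-fold higher number from compound 1 to compound 2 (0.14 log units; within the scatter) shows that changing the methoxy pattern on the carbonyl-bound ring did little, and a 4.2-fold lower number from compound 2 to compound 3 (0.62 log units; beyond the scatter) shows that removing one methoxy elsewhere gave a modest gain. Nothing shown speaks to reversing the enone. For compound 4 a step of a 1.3-fold lower number from compound 1 to compound 4 (0.10 log units; within the scatter) is therefore expected, with wide uncertainty; the estimate for compound 4 is 20000 nM, in the range 6000 nM to 60000 nM.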

Compound 4, half-maximal inhibitory concentration: 16300 nM
Compound 4: the middle estimate sits 1.2-fold (0.09 log units) above what was measured, within the range that was stated.
By their numbers in this assay, from the lowest: compounds 3, 4, 1 and 2 (each within the scatter of the next, the first and the last beyond it).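

In this assay, (2-phenylethenyl)carbonyl in place of 2-((4-methoxyphenyl)carbonyl)ethenyl on this aromatic carbon gives a 1.5-fold lower number from compound 1 to compound 4 (0.19 log units; within the scatter), so this position tolerates the reversed enone without a change beyond the scatter. The swap reverses the enone and removes the methoxy together, and this single step cannot separate the two. No measurement available here accounts for this result.

Going by these compounds, whether a methoxy group on the phenyl of the reversed enone would alter the read-out remains open. So does the outcome of placing an amine or a carboxylic acid on that phenyl.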